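Aryl replacement on the shared core: cytotoxicity notes

The source may hold more compounds than are shown below. What is called first, only, known or untested is meant among the compounds shown, and "the series" means these compounds.

Measured so far:
compound 1, `Cc1oc(-c2ccccc2Cl)nc1CN1CCC(C(=O)NCCCN2C[C@H](C)C[C@H](C)C2)CC1`: 16500 nM
compound 2, `Cc1cccc(Cl)c1-c1nc(CN2CCC(C(=O)NCCCN3CCC(C(C)C)CC3)CC2)c(C)o1`: 4910 nM

Both compounds were run in an ADME assay on Huh7.5.1 cells (Homo sapiens) for cytotoxicity, read by ATP content, with a stated time of 48 h; on this read-out lower numbers stand for higher toxicity in this test and higher numbers for lower toxicity in this test. Compound 1 gives 16500 nM, the highest of the two numbers. The nearest number belongs to compound 2, which gives 4910 nM in this assay, a gap that lies beyond the usual scatter. Compound 1 and compound 2 differ at more than one place, so no single-point step can be read from the pair.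

Compound 3, `Cc1ccc(-c2nc(CN3CCC(C(=O)NCCCN4C[C@H](C)C[C@H](C)C4)CC3)c(C)o2)c(C)c1`, is not yet measured in this assay. It departs from compound 1 at one place: 2,4-dimethylphenyl in place of 2-chlorophenyl on an aromatic carbon. Among the compounds with values here, no measured pair shows this exchange, and nothing in the two numbers at hand points to a clear direction for it. The step from compound 1 to compound 3 is therefore expected to be modest, a 1.4-fold lower number from compound 1 to compound 3 (0.14 log units; within the scatter), within or close to the scatter, leaning if anything toward a slightly lower number. Compound 3 is accordingly estimated at 12000 nM in this assay, with a range from 5000 nM to 30000 nM.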

Compound 3, half-maximal cytotoxic concentration: 4110 nM
The estimate for compound 3 lay 2.9-fold (0.47 log units) above the measured number; measured number outside the range, below it.
By their numbers in this assay, from the lowest: compounds 3 and 2 (each within the scatter of the next); then compound 1.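

Within the data shown here, this is the first single-place step: in this assay, 2,4-dimethylphenyl in place of 2-chlorophenyl on an aromatic carbon gives a 4.0-fold lower number from compound 1 to compound 3 (0.60 log units; beyond the scatter), beyond the scatter, with the rest of compound 1 unchanged. The aryl group at this place on the shared core therefore moves the number on its own, and here the move is toward higher toxicity in this test. No information on the origin of this step is available, so the result stands as an observed change only.

The exchange removes the chlorine and adds two methyl groups in a single step, so the compounds shown do not tell whether the lower number goes with the chlorine leaving, with the methyl groups entering, or with both; an unsubstituted phenyl or a phenyl carrying a single methyl group at this place would separate these readings. Also open, on these data alone, is whether the same exchange gives a step of similar size with another amine at the far end of the chain, such as the 4-isopropylpiperidine of compound 2.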